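A few compounds are considered here, and "the series" means these few. Any claim that something is new, unique, unknown or untested is made for them only; others in the source may bear on it.

In an ADME assay on L6 cells (Rattus norvegicus) for cytotoxicity, read by resazurin assay, with a stated time of 72 h (on this read-out higher numbers stand for weaker inhibition and lower numbers for stronger inhibition), compound 1 (`Cc1ccccc1C(O)(c1ccc(Cl)cc1)c1cccnc1`) gives 82000 nM and compound 2 (`OC(c1ccc(Cl)cc1)(c1cccnc1)c1cccc(Br)c1`) gives 54100 nM while compound 3 (`OC(c1ccc(Cl)cc1)(c1cccnc1)c1cccc(C(F)(F)F)c1`) gives 60400 nM in the same read-out. Compound 2 therefore stands within the scatter of both other compounds. Compound 4 (`Nc1ncc(C(O)(c2ccc(Cl)cc2)c2cccnc2)s1`) has not yet been measured. Its difference from compound 2 is 2-amino-1,3-thiazol-5-yl in place of 3-bromophenyl on a saturated chain carbon bound to two aromatic carbons and an oxygen on a saturated carbon in one place, with 2-amino-1,3-thiazol-5-yl in place of 3-bromophenyl on a saturated chain carbon bound to two aromatic carbons and an oxygen on a saturated carbon. Going by the values given here, two measured steps bear on this change. The exchange at the same place (a 1.5-fold lower number from compound 1 to compound 2 (0.18 log units; within the scatter)) and the substituent exchange on the ring (a 1.1-fold higher number from compound 2 to compound 3 (0.05 log units; within the scatter)) both stay small. Neither brings in a five-membered aromatic ring, so the series offers no direct measure of this change and the uncertainty is wide. No step beyond the scatter is expected in this assay, and neither direction is favoured. The estimated step is a 1.1-fold higher number from compound 2 to compound 4 (0.04 log units; within the scatter). For compound 4 the estimated value is 60000 nM within an expected range (22000 nM to 150000 nM).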

Compound 4, half-maximal inhibitory concentration: 56000 nM
Compound 4: the middle estimate sits 1.1-fold (0.03 log units) above what was measured; low and high end bracket the measured number.
By their numbers in this assay, from the lowest: compounds 2, 4, 3 and 1 (each within the scatter of the next).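

In this assay, placing 2-amino-1,3-thiazol-5-yl on a saturated chain carbon bound to two aromatic carbons and an oxygen on a saturated carbon gives a 1.0-fold higher number from compound 2 to compound 4 (0.01 log units; within the scatter) and a 1.5-fold lower number from compound 1 to compound 4 (0.17 log units; within the scatter). Until now this place had carried only six-membered aromatic rings of carbon only; the read-out now stays within the scatter with a five-membered aromatic ring with 2 hetero atoms, bringing 1 hydrogen-bond donor and 3 hydrogen-bond acceptors where 3-bromophenyl has 0 of each. No evidence on hand accounts for this flat result.

Going by these compounds, how a carboxylic acid or a longer alkyl chain would read at this same place remains open. Also open is whether the amino group of the 2-amino-1,3-thiazol-5-yl contributes anything to the read-out, since no compound shown separates it from the ring.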